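This account rests on a few compounds, and the source may have more. Where it says the series, first, only, none or still open, it means among the compounds named here.

Measured compounds and their values in an assay for displacement of a labelled ligand from adenosine receptor A1 (Rattus norvegicus); a lower number here means a stronger inhibitor, a higher number a weaker inhibitor:

Compound 1, `CCC(Sc1nc(S)c2cnn(-c3ccccc3)c2n1)C(N)=O`: 155 nM
Compound 2, `CCCC(Sc1nc(SC)c2cnn(-c3ccccc3)c2n1)C(N)=O`: 7.55 nM
Compound 3, `CCCC(Sc1nc(S)c2cnn(-c3ccccc3)c2n1)C(N)=O`: 56.3 nM

Compound 3 stands second highest of the three numbers in this assay. Its nearest neighbour is compound 1, and the step between them, a 2.8-fold lower number from compound 1 to compound 3 (0.44 log units; beyond the scatter), comes with a methyl in place of hydrogen on a saturated chain carbon, three bonds along the chain from a carbonyl carbon and a sulfur. The furthest value belongs to compound 2, and the step of a 7.5-fold higher number from compound 2 to compound 3 (0.87 log units; beyond the scatter) comes with hydrogen in place of methyl on a sulfur.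

Compound 4, `CC(C)C(Sc1nc(S)c2cnn(-c3ccccc3)c2n1)C(N)=O`, has not been measured. It differs from compound 3 by isopropyl in place of propyl on a saturated chain carbon bound to a carbonyl carbon and a sulfur. Among the compounds with values here, only the step from compound 1 to compound 3 bears on a change to this chain, and it was modest; the step from compound 2 to compound 3 concerns the sulfur and does not bear on it. Within the data shown here, no measured pair shows a branched chain at this position, so the direction is uncertain, and a change of modest size at most is expected. Compound 4 is therefore estimated at 80 nM, within 25 nM to 250 nM, meaning an expected step of a 1.4-fold higher number from compound 3 to compound 4 (0.15 log units; within the scatter).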

Compound 4, inhibition constant: 256 nM
Beside the measured number, compound 4's estimate is 3.2-fold (0.51 log units) below it; the measured number lies above the stated range.
By their numbers in this assay, from the lowest: compound 2; then compound 3; then compounds 1 and 4 (each within the scatter of the next).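

In this assay, the step of a 4.5-fold higher number from compound 3 to compound 4 (0.66 log units; beyond the scatter) shows that this position responds to how the chain carbons are joined and not only to how many there are: propyl and isopropyl hold the same atoms, yet the step lies beyond the scatter. The added methyl also reads differently by where it sits, with a 2.8-fold lower number from compound 1 to compound 3 (0.44 log units; beyond the scatter) on the unbranched chain, while a 1.7-fold higher number from compound 1 to compound 4 (0.22 log units; within the scatter) on the branched chain stays within the scatter. Nothing given here accounts for this difference between propyl and isopropyl.

On these data alone, it remains open whether a longer chain such as butyl or pentyl, or a ring such as cyclopropyl, would continue the trend seen with propyl or follow isopropyl. As far as these compounds go, it is also open whether methyl on the sulfur, as in compound 2, would shift the isopropyl compound as it shifts the propyl one.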